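The source may hold more compounds than are shown below. What is called first, only, known or untested is meant among the compounds shown, and "the series" means these compounds.

Values so far in an ADME assay on cells (Macrophage) for cytotoxicity, read by resazurin assay, with a stated time of 48 h; a higher number here means that more compound is tolerated, a lower number that less compound is tolerated

- compound 1 `Nc1nc(-c2ccc(Cl)cc2)cc(-c2ccc(OCc3cn(Cc4ccccc4)nn3)cc2O)n1` gives 66600 nM
- compound 2 `CCCCCCn1cc(COc2ccc(-c3cc(-c4cccc5ccccc45)nc(N)n3)c(O)c2)nn1` gives "not determined" (no result reported)
- compound 3 `CCCCCCn1cc(COc2ccc(-c3cc(-c4ccc(C(C)C)cc4)nc(N)n3)c(O)c2)nn1` gives "not determined" (no result reported)

Compound 3 therefore has no position on the numbers in this assay and cannot be ranked against anything. Compound 2 is the one further entry without a number. Among the compounds with values here, compound 1 alone has a measured value, so the series offers no step between measured compounds and no sense of how far a single change can move this read-out.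

The next compound is compound 4 `CCCCCCn1cc(COc2ccc(-c3cc(-c4ccc(Cl)cc4)nc(N)n3)c(O)c2)nn1` and it differs from compound 3 in one place. On an aromatic carbon of a six-membered aromatic ring of carbon only, para to a large group, chloro stands in place of isopropyl (chloro in place of isopropyl on an aromatic carbon). The same difference can be read as 4-isopropylphenyl to 4-chlorophenyl.

With no number for compound 3, the step itself cannot be measured from the present data. The expectation is a step no larger than the usual scatter, with no firm direction. Within the data shown here, the only anchor is compound 1 at 66600 nM and the expected value sits near it, leaning slightly toward less compound being tolerated. The estimate for compound 4 is 40000 nM with an expected range from 12000 nM to 120000 nM in this assay as the test.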

Compound 4, half-maximal cytotoxic concentration: 30300 nM
Estimate against measurement, compound 4: 1.3-fold (0.12 log units) above; the range from low to high includes it.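

Within the data shown here, measured in this assay compound 4 supplies the first readable step: pentyl in place of phenyl on a saturated chain carbon bound to an aromatic nitrogen goes with a 2.2-fold lower number from compound 1 to compound 4 (0.34 log units; beyond the scatter) in a single change to the core of compound 1, a modest move that shows this side of the molecule can shift the read-out beyond the scatter. As far as these compounds go, the change at the other end, chloro in place of isopropyl on an aromatic carbon, still cannot be read, as compound 3 has no number, so the effect of 4-chlorophenyl against 4-isopropylphenyl remains unknown. Nothing in the available data accounts for the shift seen with the chain.

The compounds shown leave open whether an amine or a carboxylic acid in place of chloro would move the number in either direction. They also leave open whether a longer chain in place of pentyl would carry the step further, and whether the same step would hold with a different group in place of chloro.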